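This account rests on a few compounds, and the source may have more. Where it says the series, first, only, none or still open, it means among the compounds named here.

In a physicochemical assay for lipophilicity, measured as octanol-water partition (a higher number here means a more lipophilic compound, a lower number a more polar compound), compound 3 (`C/C(=N\NC(=O)COc1cccc2ccccc12)c1ccccc1O`) stands lowest of the three at 3.08, with compound 1 (`C/C(=N\NC(=O)COc1cccc2ccccc12)c1ccc(C#N)cc1Br`) at 3.61 and compound 2 (`C/C(=N\NC(=O)COc1cccc2ccccc12)c1ccccc1`) at 3.65. Compound 4 (`C/C(=N\NC(=O)COc1cccc2ccccc12)c1ccc(O)cc1`) differs from compound 3 by 4-hydroxyphenyl in place of 2-hydroxyphenyl on a carbon with a double bond to nitrogen. The nearest evidence is a number 0.57 log units lower from compound 2 to compound 3 (beyond the scatter), for hydroxy in place of hydrogen, alongside a number 0.53 log units lower from compound 1 to compound 3 (beyond the scatter) and a number 0.04 log units higher from compound 1 to compound 2 (within the scatter). For the measured compounds named here, no measured pair compares these two hydroxyphenyl groups directly. Both groups carry a hydroxy, so a repeat of the modest hydroxy step is not expected. The expected change is a number 0.13 log units lower from compound 3 to compound 4 (within the scatter), a small shift within the scatter. For compound 4 the estimated value is 2.95, with an expected range of 2.6 to 3.3.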

Compound 4, partition coefficient: 4.44
Estimate against measurement, compound 4: 1.49 log units below; measured number above the stated range.
By their numbers in this assay, from the lowest: compound 3; then compounds 1 and 2 (each within the scatter of the next); then compound 4.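

In this assay, 4-hydroxyphenyl in place of 2-hydroxyphenyl gives a number 1.36 log units higher from compound 3 to compound 4 (beyond the scatter) with the same atoms, so where the hydroxy stands decides the direction of the step at this carbon. Hydroxy in place of hydrogen is no longer one step here: a number 0.79 log units higher from compound 2 to compound 4 (beyond the scatter) stands against a number 0.57 log units lower from compound 2 to compound 3 (beyond the scatter) in the opposite direction. The same split appears against 2-bromo-4-cyanophenyl, with a number 0.83 log units higher from compound 1 to compound 4 (beyond the scatter) opposed to a number 0.53 log units lower from compound 1 to compound 3 (beyond the scatter) in the same series.

On these data alone, whether an amine or a methoxy group in place of the hydroxy would split the same way stays open. Nothing shown accounts for the gap.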